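Swapping the aryl group on the ring nitrogen: compound 4

The source may report more compounds than this note shows. Statements on the series, on what has been measured and on what is new or still open speak of the compounds shown alone.

Measured compounds:
- compound 1, `Nc1scc(CN2CCN(c3ccc(Cl)cc3F)CC2)c1C(=O)c1ccc(Cl)cc1`: -9.2%
- compound 2, `Nc1scc(CN2CCN(c3cccc(C(F)(F)F)c3)CC2)c1C(=O)c1ccc(Cl)cc1`: -8.2%
- compound 3, `Nc1scc(CN2CCN(c3ccc(F)c(Cl)c3)CC2)c1C(=O)c1ccc(Cl)cc1`: 4.2%

All three share one core and differ only in the aromatic group on an amine nitrogen in a ring. In a functional assay on CHO cells with adenosine receptor A1 (Homo sapiens) as the target, read by cAMP accumulation and immunoassay, with a stated time of 6 min, tested at 0.01 uM (on this read-out lower numbers stand for a stronger effect and higher numbers for a weaker effect at the one concentration tested), compound 2 stands second highest of the three numbers; its value and that of compound 1 sit within the scatter of each other, while compound 3 lies a modest distance higher, as a number 12.4 percentage points higher from compound 2 to compound 3 (beyond the scatter) shows.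

Compound 4, `Nc1scc(CN2CCN(c3ccccc3Cl)CC2)c1C(=O)c1ccc(Cl)cc1`, is not yet measured. It differs from compound 2 by 2-chlorophenyl in place of 3-(trifluoromethyl)phenyl on an amine nitrogen in a ring. The measured steps that bear on this are all swaps of the same aromatic group at the same place: a number 1 percentage points higher from compound 1 to compound 2 (within the scatter), a number 13.4 percentage points higher from compound 1 to compound 3 (beyond the scatter) and a number 12.4 percentage points higher from compound 2 to compound 3 (beyond the scatter). Such swaps moved the read-out by at most a modest amount, and all values stay close to zero. A similar outcome is expected for compound 4, with the step of a number 5.2 percentage points higher from compound 2 to compound 4 (within the scatter) likely within the scatter. Compound 4 is estimated at -3%, in the range -17% to 11%.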

Compound 4, a percentage reported as activity, at one concentration (the size of the read-out at that concentration, not a potency): -2.1%
Compound 4: middle estimate off by 0.9 percentage points, on the low side, within the range that was stated.
By their numbers in this assay, from the lowest: compounds 1, 2, 4 and 3 (each within the scatter of the next, the first and the last beyond it).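

In this assay, the 2-chlorophenyl of compound 4 sits within the scatter of all three earlier aryl groups (a number 6.1 percentage points higher from compound 2 to compound 4 (within the scatter)), (a number 7.1 percentage points higher from compound 1 to compound 4 (within the scatter)) and (a number 6.3 percentage points lower from compound 3 to compound 4 (within the scatter)). The earlier numbers seemed to set compound 3 apart from compound 1 and compound 2, but compound 4 now fills that gap, so the four compounds no longer fall into two separate groups. Nothing available explains why these aryl groups give the numbers they do.

Going by these compounds, it remains open whether a methoxy or hydroxyl group on the phenyl ring, or a benzyl group in its place, would move the read-out further than these chlorine, fluorine and trifluoromethyl groups did. With only one concentration shown, how potent each compound is also stays unknown.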